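A Shorter Ketone Chain on the Piperazine Amide

The source may hold more compounds than are shown below. What is called first, only, known or untested is meant among the compounds shown, and "the series" means these compounds.

Among the measured compounds shown here, compound 2 `COc1ccc(CC(C)C(=O)N2CCN(c3ccc(C(F)(F)F)cc3[C@@H](N)CC(C)C)CC2)cc1` gives 120 nM in an assay on HEK293 cells for displacement of a labelled ligand from Melanocortin receptor 4 (Homo sapiens) (on this read-out lower numbers stand for stronger inhibition and higher numbers for weaker inhibition), the lowest of the two numbers measured so far. Compound 1 `CC(C)C[C@H](N)c1cc(C(F)(F)F)ccc1N1CCN(C(=O)COc2cccc(Cl)c2Cl)CC1` gives 2500 nM in this assay, and the change a 21-fold lower number from compound 1 to compound 2 (1.32 log units; beyond the scatter) shows that this position tolerates wide swings. Compound 3 `CC(C)C[C@H](N)c1cc(C(F)(F)F)ccc1N1CCN(C(=O)CCC(=O)c2ccc(Cl)cc2)CC1` carries 2-((4-chlorophenyl)carbonyl)ethyl in place of 1-(4-methoxybenzyl)ethyl on a carbonyl carbon. For the measured compounds named here, no measured step matches this exact swap, so the size of the step is uncertain. The estimate for compound 3 is a 3.3-fold higher number from compound 2 to compound 3 (0.52 log units; beyond the scatter), leaning towards a weaker result. Compound 3 is expected at 400 nM, within a range from 80 nM to 2000 nM.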

Compound 3, inhibition constant: 820 nM
Beside the measured number, compound 3's estimate is 2.1-fold (0.31 log units) below it; the measured number falls inside the stated range.
By their numbers in this assay, from the lowest: compound 2; then compound 3; then compound 1.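

In this assay the ketone chain falls short of the 1-(4-methoxybenzyl)ethyl group, with a 6.8-fold higher number from compound 2 to compound 3 (0.83 log units; beyond the scatter) even though the two groups match in heavy-atom count and each holds one aromatic ring. It still improves on the dichlorophenoxy side chain, with a 3.0-fold lower number from compound 1 to compound 3 (0.48 log units; beyond the scatter) and so places compound 3 between the other two. Nothing available explains these differences.

From the compounds shown here alone, compound 2 and compound 3 differ in several features of this one group at once, so which feature carries the step stays open. A longer chain, or an amine in place of the ketone carbonyl, could help separate them.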